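Two measured compounds and a dipropylamino isomer

The source may report more compounds than this note shows. Statements on the series, on what has been measured and on what is new or still open speak of the compounds shown alone.

Compound 1 `CCCCCOc1c(-c2cc(OC)c(OC)c(OC)c2)oc2ccccc2c1=O`: 15400 nM
Compound 2 `CCN(CC)CCCCCOc1c(-c2cc(OC)c(OC)c(OC)c2)oc2ccccc2c1=O`: 10000 nM

Among the measured compounds shown here, in a functional assay on LNCaP cells (Homo sapiens) for antiproliferative activity, read by WST assay, with a stated time of 3 days (on this read-out lower numbers stand for stronger inhibition and higher numbers for weaker inhibition), compound 2 gives 10000 nM, which lies within the scatter of compound 1, the only other compound measured. The next compound is compound 3 `CCCN(CCC)CCCOc1c(-c2cc(OC)c(OC)c(OC)c2)oc2ccccc2c1=O`, which has the same atoms as compound 2, joined differently: dipropylamino in place of 2-(diethylamino)ethyl on a saturated chain carbon, three bonds along the chain from an oxygen on an aromatic ring. For the measured compounds named here, one measured step bears on this change, the placing of diethylamino on the chain in place of hydrogen. Going by the values given here, no step beyond the scatter is expected in this assay, because a 1.5-fold lower number from compound 1 to compound 2 (0.19 log units; within the scatter) is the only measured change to this chain. Among the compounds with values here, no measured compound tests the shorter chain or the dipropylamino group, so the expectation remains loose. For compound 3 the estimate is 10000 nM, with an expected range from 4000 nM to 25000 nM. The estimated step is no change at the digits printed from compound 2 to compound 3 (within the scatter).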

Compound 3, half-maximal inhibitory concentration: 17900 nM
Compound 3: middle estimate off by 1.8-fold (0.25 log units), on the low side; low and high end bracket the measured number.
By their numbers in this assay, from the lowest: compounds 2, 1 and 3 (each within the scatter of the next).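

In this assay, exchanging 5-(diethylamino)pentyl for 3-(dipropylamino)propyl on the shared core gives a 1.8-fold higher number from compound 2 to compound 3 (0.25 log units; within the scatter) and so does not separate these two isomers. Set against the plain chain of compound 1, the dipropylamino chain gives a 1.2-fold higher number from compound 1 to compound 3 (0.07 log units; within the scatter) and so is not set apart from it either, which leaves all three compounds within the scatter of one another. Nothing available here offers any explanation for these results.

Compound 2 and compound 3 differ in both chain length and the groups on nitrogen, so the compounds shown do not tell these two changes apart. On these data alone, how a ring amine such as piperidine or morpholine, a carboxylic acid or a longer chain would read at this position also remains open.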